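Compound 3 with a 3-hydroxyphenyl in place of dichlorophenyl

The source may hold more compounds than are shown below. What is called first, only, known or untested is meant among the compounds shown, and "the series" means these compounds.

Among the compounds with values here, compound 1 `O=C(NCCCCN1CCN(c2ccc(Cl)cc2Cl)CC1)c1ccc(-c2ccsc2)cc1` stands highest of the two numbers so far in an ADME assay on microsomes from liver (Rattus norvegicus) for metabolic stability, read by LC-MS, using NADPH (a lower number here means that the compound disappears faster, a higher number that the compound lasts longer), where compound 1 gives 0.3 h. Compound 2 `COc1cccc(N2CCN(CCCCNC(=O)c3ccc(-c4ccsc4)cc3)CC2)c1` gives 0.155 h in this assay, and the step of a 1.9-fold lower number from compound 1 to compound 2 (0.29 log units; within the scatter) is the only one that bears on the next change. Compound 3 `O=C(NCCCCN1CCN(c2cccc(O)c2)CC1)c1ccc(-c2ccsc2)cc1` differs from compound 1 as follows: 3-hydroxyphenyl in place of 2,4-dichlorophenyl on an amine nitrogen in a ring Since that earlier step stayed within the scatter, the change here is expected to be small, perhaps slightly lower, as a 1.5-fold lower number from compound 1 to compound 3 (0.18 log units; within the scatter). Compound 3 is therefore estimated at 0.2 h, within a range from 0.08 h to 0.5 h.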

Compound 3, half-life: 0.085 h
Beside the measured number, compound 3's estimate is 2.4-fold (0.37 log units) above it, within the range that was stated.
By their numbers in this assay, from the lowest: compounds 3, 2 and 1 (each within the scatter of the next, the first and the last beyond it).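

In this assay, within the data shown here, the 3-hydroxyphenyl group gives a 3.5-fold lower number from compound 1 to compound 3 (0.55 log units; beyond the scatter) and so makes the first step on this amine nitrogen that lies beyond the scatter. Hydrogen in place of methyl on the oxygen gives a 1.8-fold lower number from compound 2 to compound 3 (0.26 log units; within the scatter) and so stays within the scatter, which leaves the hydroxyl and methoxy forms unseparated here. No evidence is given that accounts for the shorter half-life. On these data alone, it stays open whether the step follows from losing the chlorines or from gaining the hydroxyl. A plain phenyl or a 3-chlorophenyl on the same nitrogen would bear on that question.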